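From 4-bromophenyl to 3,4-dichlorophenyl

The source may report more compounds than this note shows. Statements on the series, on what has been measured and on what is new or still open speak of the compounds shown alone.

Compound 1 `Cc1ccc(/C=C/C(=O)Oc2ccc(/C=C3\CCCC(CN(C)C)C3=O)cc2)cc1`, compound 2 `CN(C)CC1CCC/C(=C\c2ccc(OC(=O)/C=C/c3ccc(F)cc3)cc2)C1=O` and compound 3 `CN(C)CC1CCC/C(=C\c2ccc(OC(=O)/C=C/c3ccc(Br)cc3)cc2)C1=O` share one core and differ only in the group on the aromatic carbon. In a functional assay on MOLT-4 cells (Homo sapiens) (a higher number here means a weaker inhibitor, a lower number a stronger inhibitor), compound 1 gives 3390 nM, compound 2 gives 3780 nM and compound 3 gives 3060 nM. Compound 3 holds the lowest of the three numbers, yet a 1.1-fold lower number from compound 1 to compound 3 (0.04 log units; within the scatter) and a 1.2-fold lower number from compound 2 to compound 3 (0.09 log units; within the scatter) both sit within the scatter, so no order among the three can be stated. Compound 4 `CN(C)CC1CCC/C(=C\c2ccc(OC(=O)/C=C/c3ccc(Cl)c(Cl)c3)cc2)C1=O` is the unmeasured member: 3,4-dichlorophenyl in place of 4-bromophenyl on a double-bonded chain carbon bound to a double-bonded chain carbon. All measured steps exchange a single group on that ring, a 1.1-fold higher number from compound 1 to compound 2 (0.05 log units; within the scatter), a 1.1-fold lower number from compound 1 to compound 3 (0.04 log units; within the scatter), a 1.2-fold lower number from compound 2 to compound 3 (0.09 log units; within the scatter), and none moved the number beyond the scatter. A second chlorine goes beyond any measured exchange, but the data give no direction. For compound 4 the expected step is a 1.0-fold higher number from compound 3 to compound 4 (0.02 log units; within the scatter). Compound 4 is therefore estimated at 3200 nM, within 1600 nM to 6400 nM.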

Compound 4, half-maximal inhibitory concentration: 4570 nM
Estimate against measurement, compound 4: 1.4-fold (0.15 log units) below; measured number inside the range.
By their numbers in this assay, from the lowest: compounds 3, 1, 2 and 4 (each within the scatter of the next).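

In this assay the 3,4-dichlorophenyl group leaves every step within the scatter (a 1.5-fold higher number from compound 3 to compound 4 (0.17 log units; within the scatter); a 1.2-fold higher number from compound 2 to compound 4 (0.08 log units; within the scatter); a 1.3-fold higher number from compound 1 to compound 4 (0.13 log units; within the scatter)). The position therefore accepts a second halogen on the ring, not only a single group, with no readable shift among these four compounds. Nothing available accounts for this flat result. Going by these compounds, it remains open whether a ring carrying an amine or a carboxylic acid would move the number beyond the scatter.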